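Methoxy on the Pyridine Ring of a Pyrazoline Amide

This account rests on a few compounds, and the source may have more. Where it says the series, first, only, none or still open, it means among the compounds named here.

Compound 1 `COc1ccc(C2=NN(C(=O)c3cccnc3)C(c3cn(C)c4ccc(Br)cc34)C2)cc1` gives 540 nM in a functional assay on HepG2 cells (Homo sapiens) for inhibition, read by MTT assay, with a stated time of 48 h; a higher number here means a weaker inhibitor of growth, a lower number a stronger inhibitor of growth. Compound 2 `COc1ccc(C2=NN(C(=O)c3cccnc3)C(c3cn(C)c4ccc(Br)cc34)C2)cc1OC` carries the change methoxy in place of hydrogen on an aromatic carbon and gives 2450 nM; the step is a 4.5-fold higher number from compound 1 to compound 2 (0.66 log units; beyond the scatter). Compound 3 `COc1ccc2c(c1)c(C1CC(c3ccccc3)=NN1C(=O)c1cccnc1)cn2C` rests on another core; the difference between the two cores is not broken down here. In this assay compound 3 gives 5110 nM, the highest of the three numbers. Compound 4 `COc1ccc2c(c1)c(C1CC(c3ccccc3)=NN1C(=O)c1ccc(OC)nc1)cn2C` differs from compound 3 by methoxy in place of hydrogen on an aromatic carbon. This is the same kind of change as that from compound 1 to compound 2, not the same: there the methoxy entered on a six-membered aromatic ring of carbon only, ortho to a methoxy group and meta to a large group; here it enters on a six-membered aromatic ring with one nitrogen, next to the ring nitrogen and para to a large group. Because a 4.5-fold higher number from compound 1 to compound 2 (0.66 log units; beyond the scatter) raised the number, the same direction is expected here. For compound 4 the step is estimated at a 1.9-fold higher number from compound 3 to compound 4 (0.27 log units; within the scatter). Compound 4 is expected to give about 9500 nM, between 4000 nM and 25000 nM.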

Compound 4, concentration for 50% growth inhibition: 1330 nM
Estimate against measurement, compound 4: 7.1-fold (0.85 log units) above; measured number below the stated range.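

In this assay, methoxy in place of hydrogen on the ring with one nitrogen gives a 3.8-fold lower number from compound 3 to compound 4 (0.58 log units; beyond the scatter), and set beside the earlier step, the change does not carry from one core to another in direction: the same change on two cores in this assay, a 4.5-fold higher number (0.66 log units; beyond the scatter) from compound 1 to compound 2 and a 3.8-fold lower number (0.58 log units; beyond the scatter) from compound 3 to compound 4, 17-fold (1.24 log units) apart, beyond the scatter of two such steps The methoxy also enters a different ring in each pair, so these compounds do not show whether the core or the ring taking the methoxy separates the two results. Among the compounds shown here, two pairs show only that the earlier step did not hold for compound 4, and they set no rule for other cores.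

The compounds shown leave open what 6-methoxypyridin-3-yl would do on the core of compound 1. Also open, as far as these compounds go, is how an amine or an ethoxy group would compare with methoxy in that same place on the core of compound 3.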